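A Second Aryl Swap on the Sulfonyl Sulfur

This account rests on a few compounds, and the source may have more. Where it says the series, first, only, none or still open, it means among the compounds named here.

Measured so far:
compound 1, `Cc1ccc2ncc(S(=O)(=O)c3cccc(C#N)c3)c(N3CCC(C)CC3)c2c1`, 52%
compound 2, `Cc1ccc2ncc(S(=O)(=O)c3ccc(Cl)cc3)c(N3CCC(C)CC3)c2c1`, 79%

In an assay on isolated protein for displacement of a labelled ligand from metabotropic glutamate receptor 5 (Homo sapiens), with a stated time of 60 min, tested at 1 uM (a higher number here means more inhibition at the concentration tested (going by the name of the read-out), a lower number less inhibition), compound 1 gives 52%, while compound 2 gives 79%. Among the measured compounds shown here, the one step between them, a number 27 percentage points higher from compound 1 to compound 2 (beyond the scatter), came with 4-chlorophenyl in place of 3-cyanophenyl on a sulfonyl sulfur. Compound 2 therefore stands highest of the two numbers, with compound 1 beyond the scatter below it.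

Compound 3, `Cc1ccc2ncc(S(=O)(=O)c3ccc(C)c(F)c3)c(N3CCC(C)CC3)c2c1`, is the next point. It differs from compound 2 in the same place: 3-fluoro-4-methylphenyl in place of 4-chlorophenyl on a sulfonyl sulfur

For the measured compounds named here, only one measured step bears on this change, and it shows that exchanging the aryl on the sulfonyl sulfur can move the read-out by a modest amount, in that case upward. Going by the values given here, with no second example of a ring bearing both fluorine and methyl, the direction for compound 3 is uncertain; a modest downward move toward the middle of the two measured numbers is the more cautious expectation, a number 14 percentage points lower from compound 2 to compound 3 (beyond the scatter). Compound 3 is estimated at 65%, within 45% to 85%.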

Compound 3, a percentage reported as inhibition, at one concentration (the size of the read-out at that concentration, not a potency): 91%
Compound 3: middle estimate off by 26 percentage points, on the low side, and the stated range ends below it.
By their numbers in this assay, from the lowest: compound 1; then compound 2; then compound 3.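

In this assay, the aryl group on the sulfonyl sulfur had more to give than the 4-chlorophenyl of compound 2 showed: 3-fluoro-4-methylphenyl in its place gave a number 12 percentage points higher from compound 2 to compound 3 (beyond the scatter) while the rest of the molecule stayed the same. Among the compounds shown here, measured against the 3-cyanophenyl ring, the same group gave a number 39 percentage points higher from compound 1 to compound 3 (beyond the scatter) and this is the only large step among the three compounds, so the choice of aryl group alone can move this read-out by much more than the first pair showed. The order of the three rings is clear at this one concentration, but no measurement bears on what lies behind it.

The compounds shown leave open whether the fluorine, the methyl or the two together account for the gain over compound 2, as neither 4-methylphenyl nor 3-fluorophenyl stands among them. They also leave open how the position would respond to a ring carrying a methoxy group, an amine or a carboxylic acid, and whether the order of the rings would hold in a full potency measurement.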